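Swapping the Pyridine Attachment Point in a Cytotoxicity Screen

A few compounds are considered here, and "the series" means these few. Any claim that something is new, unique, unknown or untested is made for them only; others in the source may bear on it.

Measured compounds:
compound 1, `C[C@@H](NC(=O)[C@H](CCCNC(=N)N)NC(=O)c1ccc(CN(Cc2ccccn2)C(=O)c2ccc(F)cc2)cc1)c1cccc2ccccc12`, gives 38000 nM in an ADME assay on MT4 cells (Homo sapiens) for cytotoxicity; on this read-out lower numbers stand for higher toxicity in this test and higher numbers for lower toxicity in this test;
compound 2, `C[C@@H](NC(=O)[C@H](CCCNC(=N)N)NC(=O)c1ccc(CN(Cc2cccnc2)C(=O)c2ccc(F)cc2)cc1)c1cccc2ccccc12`, gives 45000 nM in this assay;
compound 3, `C[C@H](NC(=O)[C@H](CCCNC(=N)N)NC(=O)c1ccc(CN(Cc2ccc(F)cc2)Cc2ccccn2)cc1)c1cccc2ccccc12`, gives 11000 nM in this assay.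

Compounds 1 and 2 share a core and differ only by pyridin-3-yl in place of pyridin-2-yl on a saturated chain carbon bound to an amide-type nitrogen. That change made a 1.2-fold higher number from compound 1 to compound 2 (0.07 log units; within the scatter), so the two cannot be told apart in this assay. Compound 3 has a different core; how its core differs from that of compound 1 is not broken down here, but compound 3 stands lowest of the three numbers, with both compound 1 and compound 2 beyond the scatter above it.

Compound 4, `C[C@H](NC(=O)[C@H](CCCNC(=N)N)NC(=O)c1ccc(CN(Cc2ccc(F)cc2)Cc2cccnc2)cc1)c1cccc2ccccc12`, is not yet measured. It differs from compound 3 by pyridin-3-yl in place of pyridin-2-yl on a saturated chain carbon bound to an amine nitrogen. This is the same kind of change as that from compound 1 to compound 2, yet not the same: there the pyridine sat on a saturated chain carbon bound to an amide-type nitrogen, here it sits on a saturated chain carbon bound to an amine nitrogen. Because a 1.2-fold higher number from compound 1 to compound 2 (0.07 log units; within the scatter) stayed within the scatter, the step of a 1.1-fold higher number from compound 3 to compound 4 (0.04 log units; within the scatter) is expected to be small as well. Compound 4 is therefore estimated at 12000 nM in this assay, most likely between 6000 nM and 26000 nM.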

Compound 4, half-maximal cytotoxic concentration: 41000 nM
Compound 4: the middle estimate sits 3.4-fold (0.53 log units) below what was measured, outside the stated range (above it).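

On the core of compound 3, putting pyridin-3-yl in place of pyridin-2-yl on a saturated chain carbon bound to an amine nitrogen gave a 3.7-fold higher number from compound 3 to compound 4 (0.57 log units; beyond the scatter) in this assay, so a swap that could not be detected on the core of compound 1 produced a clear step here. The size of this step did not carry over from one core to the other: the same change on two cores in this assay, a 1.2-fold higher number (0.07 log units; within the scatter) from compound 1 to compound 2 and a 3.7-fold higher number (0.57 log units; beyond the scatter) from compound 3 to compound 4, 3.1-fold (0.50 log units) apart, beyond the scatter of two such steps. Among the compounds shown here, what this does not show is which difference between the two cores goes with the gap, and with only one pair on each core it offers no rule for predicting the step on any further core.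

The compounds shown leave open how a pyridin-4-yl group would compare with pyridin-2-yl and pyridin-3-yl on either core. From the compounds shown here alone, it also remains open whether a (pyridin-3-yl)ethyl group, with its longer chain, would follow the same pattern as (pyridin-3-yl)methyl in this assay.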